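The source may report more compounds than this note shows. Statements on the series, on what has been measured and on what is new or still open speak of the compounds shown alone.

Values in a physicochemical assay for solubility, read by HPLC, measured as thermodynamic solubility, with a stated time of 4 h, at pH 6.8; on this read-out lower numbers stand for lower solubility and higher numbers for higher solubility:
- compound 1 `Cn1c(COc2cccc(C(=O)O)c2)nc2cnc(Oc3ccc(Cl)c(F)c3)cc21`: 11 ug/mL
- compound 2 `Cn1c(COc2cccc(C(=O)O)c2)nc2cnc(Oc3ccc4c(c3)OCC4)cc21`: 79 ug/mL
- compound 3 `Cc1ccnc(Oc2ccc3nc(COc4cccc(C(=O)O)c4)n(C)c3c2)c1`: 33 ug/mL

Compound 3 holds the middle place of the three in this assay. Its 33 ug/mL lies under the number of compound 2 and over that of compound 1, and both gaps are beyond the scatter.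

The next compound to be read is compound 4 `Cn1c(COc2cccc(C(=O)O)c2)nc2ccc(Oc3ncc(Cl)cc3Cl)cc21`, which keeps the core of compound 3 and changes only the group on the ether oxygen: 3,5-dichloropyridin-2-yl in place of 4-methylpyridin-2-yl on an oxygen on an aromatic ring. For the measured compounds named here, no measured step starts from compound 3 or uses this exact exchange. Going by the values given here, the one measured step at a comparable place, on an oxygen on an aromatic ring, is a 7.2-fold higher number from compound 1 to compound 2 (0.86 log units; beyond the scatter). That step is modest, is beyond the scatter, and was measured on a different core, so it is only indirect evidence. In it, the group carrying chlorine and fluorine sits on the lower side, with compound 1 at 11 ug/mL. Three compounds cannot establish a rule, but this points downward for the dichloro group, and a smaller step than the measured one is expected in this assay.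

The estimated step is a 2.8-fold lower number from compound 3 to compound 4 (0.44 log units; beyond the scatter). For compound 4 the expected value is 12 ug/mL, with an estimated range of 4 ug/mL to 35 ug/mL.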

Compound 4, solubility: 9.9 ug/mL
Estimate against measurement, compound 4: 1.2-fold (0.08 log units) above, within the range that was stated.
By their numbers in this assay, from the lowest: compounds 4 and 1 (each within the scatter of the next); then compound 3; then compound 2.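

In this assay, for the compounds shown here, 3,5-dichloropyridin-2-yl in place of 4-methylpyridin-2-yl on an oxygen on an aromatic ring gives a 3.3-fold lower number from compound 3 to compound 4 (0.52 log units; beyond the scatter) and is the first measured step on the core of compound 3. With the earlier step on the other core, a 7.2-fold higher number from compound 1 to compound 2 (0.86 log units; beyond the scatter), the read-out now moves beyond the scatter for a change at this place on two cores, although the groups exchanged differ between the two steps and no general rule follows from them. No measurement among the data shown accounts for the drop on the core of compound 3, so the step stands as an observation only.

The exchange removes the methyl group and adds two chlorine atoms in a single step, so the share of each in the lower number remains unresolved. On these data alone, how a pyridin-2-yl group carrying a single chlorine, an amine or a longer chain on this oxygen would read in this assay also remains open.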